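Exchanging the sulfonyl substituent in a mouse exposure series

A few compounds are considered here, and "the series" means these few. Any claim that something is new, unique, unknown or untested is made for them only; others in the source may bear on it.

Of the compounds shown here, two have been measured so far. In an ADME assay on the whole organism (blood, Mus musculus, strain C57BL/6) for pharmacokinetics, read by HPLC, with a stated time of 4 h, at a dose of 2 mg/kg by the intraperitoneal route (a lower number here means less compound in the circulation, a higher number more compound in the circulation at the dose given), compound 1 (`CC(C)S(=O)(=O)c1c(Cl)ccc(NC(=O)Nc2cccc(Cl)c2Cl)c1O`) gives 290 ng.h/mL and compound 2 (`CN1CC2(CC(S(=O)(=O)c3c(Cl)ccc(NC(=O)Nc4cccc(F)c4Cl)c3O)C2)C1`) gives 1050 ng.h/mL as the area under the concentration-time curve. Compound 2 therefore stands highest of the two, and the gap between them lies beyond the scatter. The two compounds differ in more than one place, so their values do not isolate the effect of any single change.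

Compound 3 (`CCN1CCN(S(=O)(=O)c2c(Cl)ccc(NC(=O)Nc3cccc(F)c3Cl)c2O)CC1`) departs from compound 2 only on the sulfonyl sulfur, where a group of 8 heavy atoms (6 carbon, 2 nitrogen; one six-membered non-aromatic ring with 2 hetero atoms) in place of a group of 8 heavy atoms (7 carbon, 1 nitrogen; one four-membered non-aromatic ring of carbon only, one four-membered non-aromatic ring with 1 hetero atom), on a sulfonyl sulfur and the incoming group is 4-ethylpiperazin-1-yl. Among the compounds with values here, no measured pair shows this exchange, so the expectation starts from compound 2 at 1050 ng.h/mL and carries a wide margin. A modest fall in this assay is expected, with a 1.5-fold lower number from compound 2 to compound 3 (0.18 log units; within the scatter) estimated to stay within the scatter. For compound 3 the expected value is 700 ng.h/mL with an estimated range from 250 ng.h/mL to 2000 ng.h/mL in this measure.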

Compound 3, area under the concentration-time curve: 189 ng.h/mL
Beside the measured number, compound 3's estimate is 3.7-fold (0.57 log units) above it, and the stated range ends above it.
By their numbers in this assay, from the lowest: compounds 3 and 1 (each within the scatter of the next); then compound 2.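

Within the data shown here, the exchange on the sulfonyl sulfur gives the first comparison in which only one place differs: in this assay, the 4-ethylpiperazin-1-yl group brings a 5.6-fold lower number from compound 2 to compound 3 (0.74 log units; beyond the scatter), so this position alone can move the area under the curve by more than the scatter. The change takes place with no difference in the counts of heavy atoms, hydrogen-bond donors or hydrogen-bond acceptors, and neither group carries a net charge, so these counts do not separate the two groups; what differs is the ring arrangement and the number of ring nitrogens. Nothing measured here bears on why the number falls.

The compounds shown leave open whether the step follows from the piperazine ring itself or from its ethyl group, a question that a methyl group in place of the ethyl, or a morpholine on the sulfonyl sulfur, would address. They also leave open whether other small amines on this sulfur, such as an azetidine or a pyrrolidine, would lie nearer compound 2 or compound 3.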